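Formyl in place of methyl on compound 2

The source may hold more compounds than are shown below. What is called first, only, known or untested is meant among the compounds shown, and "the series" means these compounds.

Compound 1 `CC1Cn2cc([N+](=O)[O-])nc2O1`: > 500000 nM, a limit
Compound 2 `Cc1ccc(-c2c([N+](=O)[O-])nc3n2CC(C)O3)cc1`: > 250000 nM, a limit
Compound 3 `CC1Cn2c(nc([N+](=O)[O-])c2-c2cccc(C#N)c2)O1`: > 500000 nM, a limit

None of the three compounds has yielded a number in an ADME assay on CHO cells (Cricetulus griseus) for cytotoxicity, read by MTT assay, with a stated time of 24 h; a lower number here means that less compound is tolerated, a higher number that more compound is tolerated. Compound 2 stands only at a limit, > 250000 nM. Compound 1 and compound 3 likewise stand at limits. Compound 4 `CC1Cn2c(nc([N+](=O)[O-])c2-c2ccc(C=O)cc2)O1` differs from compound 2 by having formyl in place of methyl on an aromatic carbon, para to a large group: formyl in place of methyl on an aromatic carbon. Among the measured compounds shown here, no measured pair shows what such a change does. The expected change in this assay, a step that the limit leaves unreadable from compound 2 to compound 4, is estimated to lie within the scatter, with no firm direction. Compound 4 is expected at 300000 nM, with an estimated range from 100000 nM to 600000 nM.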

Compound 4, half-maximal cytotoxic concentration: 255000 nM
The estimate for compound 4 lay 1.2-fold (0.07 log units) above the measured number; the range from low to high includes it.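

No step can be read from compound 2 to compound 4 in this assay, because compound 2 stands only at a limit: the limit of > 250000 nM in this assay, at which 1 of the 4 values shown sits.

The compounds shown leave open what formyl in place of methyl on an aromatic carbon does in this assay.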